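This account rests on a few compounds, and the source may have more. Where it says the series, first, only, none or still open, it means among the compounds named here.

Measured so far in a functional assay on HaCaT cells (Homo sapiens) for antiproliferative activity, read by sulforhodamine B assay, with a stated time of 3 days; on this read-out higher numbers stand for weaker inhibition and lower numbers for stronger inhibition:
compound 1 `COC(=O)c1cc(CCc2ccccc2OC)ccc1O` gives 20000 nM here
compound 2 `COC(=O)c1cc(CCc2cccc(OC)c2)ccc1O` gives 37000 nM here
compound 3 `COC(=O)c1cc(CCc2c(OC)cccc2OC)ccc1O` gives 110 nM here

Compound 2 sits with compound 1 at the high end of these numbers. The two are within the scatter of each other, and compound 3 lies far lower than both.

Next is compound 4 `COC(=O)c1cc(CCc2cc(OC)ccc2C(C)=O)ccc1O`, which has acetyl in place of hydrogen on an aromatic carbon of compound 2, ortho to a large group and para to a methoxy group (acetyl in place of hydrogen on an aromatic carbon).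

One measured step adds a group on an aromatic carbon: a 180-fold lower number from compound 1 to compound 3 (2.26 log units; beyond the scatter) is large and beyond the scatter, with methoxy in place of hydrogen. Among the compounds with values here, it bears on the new change only loosely, since the entering group there is methoxy and no measured compound carries acetyl. It also starts from a different compound.

In this assay a step towards a lower number is therefore expected, clearly smaller than that one, and a step within the scatter cannot be ruled out. The estimated change is a 7.4-fold lower number from compound 2 to compound 4 (0.87 log units; beyond the scatter) on present evidence. For compound 4 the expected value is 5000 nM with an estimated range from 600 nM to 40000 nM for now.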

Compound 4, half-maximal inhibitory concentration: 41 nM
Compound 4: middle estimate off by 120-fold (2.09 log units), on the high side; measured number below the stated range.
By their numbers in this assay, from the lowest: compound 4; then compound 3; then compounds 1 and 2 (each within the scatter of the next).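

In this assay, the position ortho to a large group and para to a methoxy group on the ring of compound 2 tolerates acetyl in place of hydrogen and responds strongly, with a 900-fold lower number from compound 2 to compound 4 (2.96 log units; beyond the scatter) as a large step beyond the scatter. Until now the only measured gain from a new group on an aromatic carbon was the methoxy step, a 180-fold lower number from compound 1 to compound 3 (2.26 log units; beyond the scatter) in the same assay, so a large step on entry of a group is no longer confined to methoxy or to a single starting compound, although two steps from different compounds set no general rule. The measurements shown give no explanation for the size of the acetyl step.

Still open, on these data alone, is how much of this step depends on the acetyl group itself, since a single entering group at this carbon cannot separate its carbonyl from its size or from the methoxy group para to it. Placing a carboxylic acid, an amine or a longer acyl chain at the same carbon, or acetyl on the core of compound 1, would address how specific the change is.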